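Amide and sulfonamide variants on the shared core

The source may hold more compounds than are shown below. What is called first, only, known or untested is meant among the compounds shown, and "the series" means these compounds.

Of the compounds shown here, three on the shared core have been measured in a functional assay on B16-F10 cells (Mus musculus) for antiproliferative activity, read by MTT assay, with a stated time of 48 h; a lower number here means a stronger inhibitor, a higher number a weaker inhibitor. Compound 1 `COc1ccc(-c2cn3cc(C4=CCN(C(=O)c5cccc(C(F)(F)F)c5)CC4)ccc3n2)cc1OC` gives 7890 nM. Compound 2 `COc1ccc(-c2cn3cc(C4=CCN(C(=O)c5ccccc5C(F)(F)F)CC4)ccc3n2)cc1OC` gives 8110 nM. Compound 3 `COc1ccc(-c2cn3cc(C4=CCN(S(=O)(=O)C5CCCC5)CC4)ccc3n2)cc1OC` gives 7690 nM. All three numbers sit together: the step of a 1.0-fold higher number from compound 1 to compound 2 (0.01 log units; within the scatter), the step of a 1.0-fold lower number from compound 1 to compound 3 (0.01 log units; within the scatter) and the step of a 1.1-fold lower number from compound 2 to compound 3 (0.02 log units; within the scatter) are each within the scatter, so compound 3 stands level with compound 1 and compound 2 rather than apart from them.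

Compound 4 `COc1ccc(-c2cn3cc(C4=CCN(C(=O)c5ccccc5)CC4)ccc3n2)cc1OC` is not yet measured. Its difference from compound 3 is benzoyl in place of cyclopentylsulfonyl on an amine nitrogen in a ring. The measured steps that bear on this are those from compound 1 and compound 2 to compound 3, where an aryl carbonyl group gave way to cyclopentylsulfonyl without a step beyond the scatter. Compound 4 reverses that kind of exchange, bringing back a carbonyl-linked aromatic ring in the form of benzoyl, which differs from the aryl carbonyl groups of compound 1 and compound 2 only in lacking trifluoromethyl. No step beyond the scatter is therefore expected in this assay; the step of a 1.0-fold higher number from compound 3 to compound 4 (0.01 log units; within the scatter) is estimated to be small.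

Compound 4 is expected to give 7900 nM, within a range of 4000 nM to 16000 nM.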

Compound 4, half-maximal inhibitory concentration: 8370 nM
Compound 4: the middle estimate sits 1.1-fold (0.03 log units) below what was measured, within the range that was stated.
By their numbers in this assay, from the lowest: compounds 3, 1, 2 and 4 (each within the scatter of the next).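

Hydrogen in place of trifluoromethyl on an aromatic carbon gives a 1.0-fold higher number from compound 2 to compound 4 (0.01 log units; within the scatter) and a 1.1-fold higher number from compound 1 to compound 4 (0.03 log units; within the scatter) in this assay, so among these compounds the aryl carbonyl group needs no trifluoromethyl to stay level, whichever of the two trifluoromethyl names it carries. Benzoyl in place of cyclopentylsulfonyl on the amine nitrogen in a ring gives a 1.1-fold higher number from compound 3 to compound 4 (0.04 log units; within the scatter) and extends the earlier carbonyl-to-sulfonyl comparison to an aromatic ring with no substituent, and that exchange again produces no step beyond the scatter. All four compounds now stand level in this assay, so neither the linking group nor the trifluoromethyl group has separated any compound from the others at this position.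

Open, as far as these compounds go, is whether a different kind of group on this nitrogen, such as a chain ending in an amine or a benzoyl group carrying a carboxylic acid, would move the number beyond the scatter, or whether changes elsewhere on the shared core are needed to do so. No supporting data accompany these values to explain why the numbers stay level.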